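Ester to Ketone on the Phenyl Side Chain

The compounds below may be only part of what the source reports. "The series", "measured", "known", "first", "only" and "open" are said of these compounds alone.

Within the data shown here, compound 2 `CCOC(=O)c1ccccc1CC[C@H](SC[C@@H](C)C(=O)O)c1cccc(/C=C/c2ccc3ccc(Cl)cc3n2)c1` gives 3.7 nM in an assay on membranes from lung for inhibition of cysteinyl leukotriene receptor 1 (Cavia porcellus) (a higher number here means a weaker inhibitor, a lower number a stronger inhibitor), the higher of the two numbers measured; its nearest neighbour, compound 1 `C[C@H](CS[C@@H](CCc1ccccc1CC(C)(C)O)c1cccc(/C=C/c2ccc3ccc(Cl)cc3n2)c1)C(=O)O`, gives 1 nM, and the step of a 3.7-fold higher number from compound 1 to compound 2 (0.57 log units; beyond the scatter) is the only measured step. Compound 3 `CC(=O)c1ccccc1CC[C@H](SC[C@@H](C)C(=O)O)c1cccc(/C=C/c2ccc3ccc(Cl)cc3n2)c1` differs from compound 2 at one place: methyl in place of ethoxy on a carbonyl carbon. Among the measured compounds shown here, no measured step touches the carbonyl substituent, so the exchange of ethoxy for methyl has no direct precedent in these numbers, and the expected step of a 1.1-fold higher number from compound 2 to compound 3 (0.03 log units; within the scatter) is therefore one within the scatter, in no clear direction. Compound 3 is estimated at 4 nM, with a range from 1.5 nM to 12 nM.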

Compound 3, half-maximal inhibitory concentration: 3 nM
For compound 3 the middle estimate is 1.3-fold (0.12 log units) above the measured one, and the stated range covers the measured number.
By their numbers in this assay, from the lowest: compound 1; then compounds 3 and 2 (each within the scatter of the next).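

In this assay the substituent on the carbonyl carbon can go from ethoxy to methyl with a 1.2-fold lower number from compound 2 to compound 3 (0.09 log units; within the scatter) and no change beyond the scatter. Acetyl therefore reads like ethoxycarbonyl here, and the gap to the 2-hydroxy-2-methylpropyl group of compound 1 remains, with a 3.0-fold higher number from compound 1 to compound 3 (0.48 log units; beyond the scatter) as its measure. Nothing shown here offers a measured explanation for either step.

As far as these compounds go, it remains open whether an amine on that carbonyl carbon, giving an amide, or a hydroxyl, giving a carboxylic acid, would read the same. A longer chain in place of methyl also remains untested in the compounds shown.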